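Bromobenzyl in Place of a Halogenated Phenyl on the Piperazine Nitrogen

The source may report more compounds than this note shows. Statements on the series, on what has been measured and on what is new or still open speak of the compounds shown alone.

Of the compounds shown here, three sharing one core have been measured in an assay on CHO cells for displacement of a labelled ligand from adenosine receptor A2b (Homo sapiens), read by scintillation counting, with a stated time of 75 min, in the presence of a further agent that is not named here; on this read-out lower numbers stand for stronger inhibition and higher numbers for weaker inhibition. Compound 1 `CCCn1c(=O)[nH]c2nc(-c3ccc(S(=O)(=O)N4CCN(c5ccc(Br)cc5)CC4)cc3)[nH]c2c1=O` gives 0.0835 nM, compound 2 `CCCn1c(=O)[nH]c2nc(-c3ccc(S(=O)(=O)N4CCN(c5ccccc5)CC4)cc3)[nH]c2c1=O` gives 0.643 nM, and compound 3 `CCCn1c(=O)[nH]c2nc(-c3ccc(S(=O)(=O)N4CCN(c5ccc(Cl)cc5F)CC4)cc3)[nH]c2c1=O` gives 1.91 nM. Compound 3 thus stands highest of the three: a 23-fold higher number from compound 1 to compound 3 (1.36 log units; beyond the scatter) and a 3.0-fold higher number from compound 2 to compound 3 (0.47 log units; beyond the scatter), both beyond the scatter. Among the measured steps, a 7.7-fold higher number from compound 1 to compound 2 (0.89 log units; beyond the scatter) shows that the bromo on the aromatic carbon is tied to the lowest number of the set.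

Compound 4 `CCCn1c(=O)[nH]c2nc(-c3ccc(S(=O)(=O)N4CCN(Cc5cccc(Br)c5)CC4)cc3)[nH]c2c1=O` differs from compound 3 in one place: 3-bromobenzyl in place of 4-chloro-2-fluorophenyl on an amine nitrogen in a ring. The measured steps bear on this only in part. Going by the values given here, the step from compound 3 to compound 4 keeps a bromine on the aromatic ring, as in compound 1, but none of the measured steps places a benzyl rather than a directly bound aromatic ring on the ring nitrogen, so that part of the change has no precedent here. Given that compound 3 gives 1.91 nM and that the bromo-bearing compound 1 gives 0.0835 nM, a modest move toward a lower number is expected in this assay, with wide uncertainty.

The expected change is a 1.9-fold lower number from compound 3 to compound 4 (0.28 log units; within the scatter). Compound 4 is therefore estimated at 1 nM, within a range from 0.2 nM to 5 nM.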

Compound 4, inhibition constant: 0.148 nM
Estimate against measurement, compound 4: 6.8-fold (0.83 log units) above; measured number outside the range, below it.
By their numbers in this assay, from the lowest: compounds 1 and 4 (each within the scatter of the next); then compound 2; then compound 3.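

In this assay, going by these compounds alone, the 3-bromobenzyl group, with the same count of heavy atoms as the 4-chloro-2-fluorophenyl it replaces, gives a 13-fold lower number from compound 3 to compound 4 (1.11 log units; beyond the scatter), and against the plain phenyl it gives a 4.3-fold lower number from compound 2 to compound 4 (0.64 log units; beyond the scatter); a benzyl on this ring nitrogen is therefore compatible with a low number, which no earlier compound could show. With a 1.8-fold higher number from compound 1 to compound 4 (0.25 log units; within the scatter), compounds 1 and 4 cannot be ordered, and the two bromine-bearing compounds, one with a directly bound aromatic ring and one with a benzyl, both stand below compound 2 and compound 3, which carry no bromine. Nothing measured here explains the size of these steps.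

Compound 4 differs from the others both in the benzyl carbon and in the bromo substituent at once, so the compounds shown leave open how much of the step belongs to each. From the compounds shown here alone, an unsubstituted benzyl, a 4-bromobenzyl or a longer chain such as 2-phenylethyl on the same nitrogen would separate those two parts, and how the place of the bromine on the benzyl ring bears on the number also stays open.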